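Nitro series: removing the hydroxy from compound 3

The compounds below may be only part of what the source reports. "The series", "measured", "known", "first", "only" and "open" are said of these compounds alone.

Measured in a functional assay on the whole organism (Hindlimb, strain albino) with Mus musculus as the target, in the maximal electroshock model, with a stated time of 0.5 h; a higher number here means that more compound is needed for the effect, a lower number that less compound is needed:
- compound 1 (`COc1ccc(C2CC(Nc3nc4ccc([N+](=O)[O-])cc4s3)=NN2C(C)=O)cc1`): 145 umol/kg
- compound 2 (`CC(=O)N1N=C(Nc2nc3ccccc3s2)CC1c1ccccc1`): 315 umol/kg
- compound 3 (`CC(=O)N1N=C(Nc2nc3ccc([N+](=O)[O-])cc3s2)CC1c1ccc(O)cc1`): 162 umol/kg

Compound 3 lies within the scatter of both other measured compounds, so the three values give it no clear rank. The next compound to consider is compound 4 (`CC(=O)N1N=C(Nc2nc3ccc([N+](=O)[O-])cc3s2)CC1c1ccccc1`), which is reached from compound 3 by hydrogen in place of hydroxy on an aromatic carbon.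

Going by the values given here, only one measured step touches this substituent: a 1.1-fold higher number from compound 1 to compound 3 (0.05 log units; within the scatter). That step replaces methyl on the oxygen and leaves the oxygen in place, so it bears on the change only indirectly. Among the compounds with values here, no measured step removes the oxygen itself. Compound 2 shares the phenyl of compound 4 but lacks the nitro group, and compound 2 gives 315 umol/kg. With so little evidence, no shift beyond the scatter is expected in this assay, and no direction is favoured with any confidence.

The expected step is a 1.0-fold higher number from compound 3 to compound 4 (0.02 log units; within the scatter). Compound 4 is estimated at 170 umol/kg, with an expected range of 90 umol/kg to 320 umol/kg.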

Compound 4, dose for half-maximal effect: 216 umol/kg
The estimate for compound 4 lay 1.3-fold (0.10 log units) below the measured number; measured number inside the range.
By their numbers in this assay, from the lowest: compounds 1, 3, 4 and 2 (each within the scatter of the next, the first and the last beyond it).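

Notes on the aromatic position: in this assay the change from 4-hydroxyphenyl to phenyl gives a 1.3-fold higher number from compound 3 to compound 4 (0.12 log units; within the scatter) and so adds a step that removes the oxygen itself, which the earlier methyl step on that oxygen could not show. Replacing methoxy at the same place gives a 1.5-fold higher number from compound 1 to compound 4 (0.17 log units; within the scatter), so hydroxy, methoxy and hydrogen at this position are not told apart by this read-out, and the position tolerates loss of the oxygen without a shift beyond the scatter. Going by these compounds alone, with phenyl held constant, the first direct step on the nitro group, a 1.5-fold lower number from compound 2 to compound 4 (0.16 log units; within the scatter), also stays within the scatter, so this single change is not resolved either. No supporting evidence bears on these results.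

Open at this position is whether any other group, such as an amine, a carboxylic acid or a longer chain on the oxygen, would move the number beyond the scatter. Also open is whether hydroxy and methoxy read the same way without the nitro group, since compound 2 is the only compound shown that lacks it.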